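The source may report more compounds than this note shows. Statements on the series, on what has been measured and on what is new or still open speak of the compounds shown alone.

Measured so far in a functional assay on MCF7 cells (Homo sapiens) for antiproliferative activity, read by MTT assay, with a stated time of 72 h; a lower number here means a stronger inhibitor, a higher number a weaker inhibitor:
- compound 1 `CC/C=C/C(=O)Nc1cccc(Oc2nc(Nc3ccn(C)n3)nc3c2CSCC3)c1`: > 50000 nM (a limit, not a number)
- compound 2 `CC(C)=CC(=O)Nc1cccc(Oc2nc(Nc3ccn(C)n3)nc3c2CSCC3)c1`: > 50000 nM (a limit, not a number)

Compound 2 therefore stands only at a limit, with no exact value. Compound 3 `COc1cccc(Nc2nc3c(c(Oc4cccc(NC(=O)C=C(C)C)c4)n2)CSCC3)c1` keeps the rest of compound 2 and changes one group: 3-methoxyphenyl in place of 1-methyl-1H-pyrazol-3-yl on a nitrogen on an aromatic ring. Going by the values given here, the only measured step, a step that the two limits leave unreadable from compound 1 to compound 2, lies at a different place, on a carbonyl carbon, and gives no size to carry over. Among the compounds with values here, the sole guide is the limit of > 50000 nM in this assay, at which 2 of the 2 values shown sit, so compound 3 is expected to stay weak in this assay, with no clear direction beyond a possible small gain. The expected change is an at least 1.6-fold lower number from compound 2 to compound 3 (0.22 log units; that floor lies within the scatter). The estimate for compound 3 is 30000 nM, with an expected range of 8000 nM to 60000 nM.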

Compound 3, half-maximal inhibitory concentration: > 50000 nM
Compound 3: a limit, no number; the forecaster's own chance of this, stated with the estimate: 55%; middle value at least 1.6-fold (0.22 log units) away from the limit.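

Going by these compounds alone, compound 2 and compound 3 each stand only at a limit, so no step between them can be read: the limit of > 50000 nM in this assay, at which 3 of the 3 values shown sit. The compounds shown leave open whether any group on this shared core gives an exact value in this assay.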